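Removing a Methylsulfonyl Group from a Pyridine Amine

This account rests on a few compounds, and the source may have more. Where it says the series, first, only, none or still open, it means among the compounds named here.

Measured compounds:
Compound 1 `C[C@H](NC(=O)c1ccc(-c2ccc(N)nc2)cc1)C(=O)Nc1ccc(Cl)c(C(F)(F)F)c1` gives 5950 nM in a functional assay on K562 cells (Homo sapiens) for inhibition, read by MTT assay, with a stated time of 48 h; on this read-out lower numbers stand for stronger inhibition and higher numbers for weaker inhibition.
Compound 2 `CS(=O)(=O)Nc1ccc(-c2cccc(C(=O)N[C@H]3CN[C@@H](C(=O)Nc4ccc(Cl)c(C(F)(F)F)c4)C3)c2)cn1` gives 24600 nM in this assay.
Compound 3 `C[C@H](NC(=O)c1ccc(-c2ccc(NS(C)(=O)=O)nc2)cc1)C(=O)Nc1ccc(Cl)c(C(F)(F)F)c1` gives 7240 nM in this assay.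

Compound 2 stands highest of the three. The difference between the core of compound 2 and the core of compound 3 is not broken down here. Compound 3 and compound 1 differ in one place: hydrogen in place of methylsulfonyl on a nitrogen on an aromatic ring. That change gave a 1.2-fold lower number from compound 3 to compound 1 (0.09 log units; within the scatter).

Compound 4 `Nc1ccc(-c2cccc(C(=O)N[C@H]3CN[C@@H](C(=O)Nc4ccc(Cl)c(C(F)(F)F)c4)C3)c2)cn1` is not yet measured and is related to compound 2 by the same change: hydrogen in place of methylsulfonyl on a nitrogen on an aromatic ring. The place is the same in both pairs, so this is the same change. In this assay the expected step is a 1.2-fold lower number from compound 2 to compound 4 (0.09 log units; within the scatter), because the matching step a 1.2-fold lower number from compound 3 to compound 1 (0.09 log units; within the scatter) lies within the scatter. Compound 4 is therefore estimated at 20000 nM, with a likely range from 8000 nM to 50000 nM.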

Compound 4, half-maximal inhibitory concentration: 20000 nM
The estimate for compound 4 equals the measured number at the digits printed; the measured number falls inside the stated range.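

In this assay, putting hydrogen in place of methylsulfonyl on a nitrogen on an aromatic ring gives a 1.2-fold lower number from compound 2 to compound 4 (0.09 log units; within the scatter) and so leaves no measurable difference on this second core. The two cores agree closely: the same change on two cores in this assay, a 1.2-fold lower number (0.09 log units; within the scatter) from compound 3 to compound 1 and a 1.2-fold lower number (0.09 log units; within the scatter) from compound 2 to compound 4, 1.0-fold (0.00 log units) apart, within the scatter of two such steps. This shows that the change made no measurable difference on either core, but two cores in one cell assay are too few to support a general rule for the series, and the data do not explain why the change has so little effect.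

Going by these compounds, it remains open whether an acetyl group or a longer chain such as ethylsulfonyl on that nitrogen would also leave the number unchanged. On these data alone, it also remains open whether a third core would behave the same way.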